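A few compounds are considered here, and "the series" means these few. Any claim that something is new, unique, unknown or untested is made for them only; others in the source may bear on it.

Measured so far:
- Compound 1, `CCC(CC)C(N)CCN(C(=O)[C@@H]1C[C@H]1c1ccccc1)c1ccc(-c2ccccc2)cc1`, gives 2 nM in a functional assay for agonist activity at G protein-coupled receptor 88 (Homo sapiens), read by HTRF and cAMP accumulation; a lower number here means that less compound is needed, a higher number that more compound is needed for the effect.
- Compound 2, `CC[C@H](C)[C@H](N)CN(C(=O)[C@@H]1C[C@H]1c1cncnc1)c1ccc(-c2ccccc2)cc1`, gives 19000 nM in this assay.
- Compound 3, `CC(C)C[C@H](N)CN(C(=O)[C@@H]1C[C@H]1c1ccccc1)c1ccc(-c2ccoc2)cc1`, gives 2000 nM in this assay.

Among these three numbers, compound 3 stands second highest. Its nearest neighbour is compound 2, whose number is higher by a gap that lies beyond the scatter; the furthest is compound 1, whose number is lower by a gap far beyond the scatter. For the measured compounds named here, no single-change step between two measured compounds is available, so the effect of any one change has to be judged from the compounds as they stand.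

Compound 4, `COc1ccccc1-c1ccc(N(C[C@@H](N)CC(C)C)C(=O)[C@@H]2C[C@H]2c2ccccc2)cc1`, is the next compound to be measured. It differs from compound 3 in one place: 2-methoxyphenyl in place of furan-3-yl on an aromatic carbon. Compound 1, which carries a six-membered carbon-only ring at that place, shows the lowest number here, though it also differs from compound 3 elsewhere. The step from compound 3 to compound 4 is therefore expected to be downward and beyond the scatter, at about a 20-fold lower number from compound 3 to compound 4 (1.30 log units; beyond the scatter). Compound 4 is estimated at 100 nM, within a range from 10 nM to 1000 nM.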

Compound 4, half-maximal effective concentration: 3200 nM
Compound 4: the middle estimate sits 32-fold (1.51 log units) below what was measured; measured number outside the range, above it.
By their numbers in this assay, from the lowest: compound 1; then compounds 3 and 4 (each within the scatter of the next); then compound 2.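

At this position on the shared core, in this assay, putting 2-methoxyphenyl in place of furan-3-yl gives a 1.6-fold higher number from compound 3 to compound 4 (0.20 log units; within the scatter). The position therefore takes a six-membered aromatic ring of carbon only, with 8 heavy atoms instead of 5, without a change beyond the scatter, so a ring of this kind with a methoxy group does not by itself bring the number toward that of compound 1. Nothing shown here gives a measured reason why these two groups read alike.

Compound 1 differs from compound 3 in more than one place, so what lies behind its number stays open, including the part played by the unsubstituted phenyl ring at this position. Also open, on these data alone, is how an amine or a carboxylic acid on this aromatic ring would read.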